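Swapping the pyridinyl arm of compound 1 for a methoxyphenyl

The compounds below may be only part of what the source reports. "The series", "measured", "known", "first", "only" and "open" are said of these compounds alone.

Of the compounds shown here, three sharing one core have been measured in an assay on isolated protein for inhibition of aldehyde dehydrogenase 1A1 (Homo sapiens); a lower number here means a stronger inhibitor, a higher number a weaker inhibitor. Compound 1, `CC(Sc1nc2c(cnn2C)c(=O)n1-c1ccccc1)c1ccccn1`, gives 242 nM. Compound 2, `CC(Sc1nc2nn(C3COC3)cc2c(=O)n1-c1ccccc1)c1ccccc1`, gives 109 nM, and compound 3, `Cn1ncc2c(=O)n(-c3ccccc3)c(/C=C/c3cccc(F)c3)nc21`, gives 270 nM. Among these three numbers compound 1 stands second highest: compound 3 lies within the scatter of it, while compound 2 lies beyond the scatter with a lower number, so compound 2 is the only one of the three that can be called a stronger inhibitor than compound 1.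

The next compound, compound 4, `COc1ccccc1C(C)Sc1nc2c(cnn2C)c(=O)n1-c1ccccc1`, is drawn from compound 1 by one change: 2-methoxyphenyl in place of pyridin-2-yl on a saturated chain carbon bound to a saturated chain carbon and a sulfur. Among the measured compounds shown here, no pair of measured compounds differs by this change alone, so the step has no measured counterpart. The account expects compound 4 to land close to compound 1 in this assay, with a step of a 1.5-fold lower number from compound 1 to compound 4 (0.18 log units; within the scatter) that is small and, if anything, toward a lower number, since compound 2, carrying a carbon-only ring on the same chain carbon, gives 109 nM. Compound 4 is therefore estimated at 160 nM, within a range of 55 nM to 480 nM.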

Compound 4, half-maximal inhibitory concentration: 445 nM
Estimate against measurement, compound 4: 2.8-fold (0.44 log units) below; low and high end bracket the measured number.
By their numbers in this assay, from the lowest: compound 2; then compounds 1, 3 and 4 (each within the scatter of the next).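

Among the compounds shown here, the swap gives the first direct reading at this position: the step of a 1.8-fold higher number from compound 1 to compound 4 (0.26 log units; within the scatter) in this assay stays within the scatter, so the two compounds cannot be ranked. On the saturated chain carbon bound to a saturated chain carbon and a sulfur, then, a ring of carbon only bearing a methoxy group reads the same, within the scatter, as pyridin-2-yl, and the ring nitrogen is not needed for inhibition in this range. Nothing shown gives a reason for this reading.

From the compounds shown here alone, whether a plain phenyl on the core of compound 1 would read the same as these two rings remains open, since compound 2 differs from compound 1 in more than one place. Also open, going by these compounds, is how this position would respond to a ring carrying an amine or a carboxylic acid.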